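Compound 3 loses its 3,5-dimethoxyphenyl group

A few compounds are considered here, and "the series" means these few. Any claim that something is new, unique, unknown or untested is made for them only; others in the source may bear on it.

In a functional assay on U-87MG ATCC cells for antiproliferative activity against U-87 MG (Homo sapiens), read by spectrophotometry, with a stated time of 2 days (a higher number here means a weaker inhibitor of growth, a lower number a stronger inhibitor of growth), compound 3 `COc1cc(Nc2ncc(C(F)(F)F)c(N3Cc4cccc(N(C)S(C)(=O)=O)c4C3)n2)cc(OC)c1` gives > 30000 nM, which is a limit and not a number. Compound 2 `Cc1ccc(Nc2ncc(C(F)(F)F)c(N3Cc4cccc(N(C)S(C)(=O)=O)c4C3)n2)c(Cl)c1` gives > 30000 nM, also a limit. The series thus shows (the limit of > 30000 nM in this assay, at which 2 of the 3 values shown sit). Only compound 1 `CC(=O)N1CCN(c2ccc(Nc3ncc(C(F)(F)F)c(N4Cc5cccc(N(C)S(C)(=O)=O)c5C4)n3)cc2)CC1` gives a number, 22100 nM. Compound 4 `CN(c1cccc2c1CN(c1nc(Nc3cc(Cl)cc(C(F)(F)F)c3)ncc1C(F)(F)F)C2)S(C)(=O)=O` carries 3-chloro-5-(trifluoromethyl)phenyl in place of 3,5-dimethoxyphenyl on a nitrogen on an aromatic ring. For the measured compounds named here, the one measured step touching this place, a step that the two limits leave unreadable from compound 2 to compound 3, offers no size to build on. With so little to go on, only a small move towards stronger inhibition, if any, is expected: an at least 1.2-fold lower number from compound 3 to compound 4 (0.07 log units; that floor lies within the scatter). Compound 4 is estimated at 25000 nM, in a range from 10000 nM to 42000 nM, and it may well return only a limit.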

Compound 4, concentration for 50% growth inhibition: 5500 nM
Compound 4: middle estimate off by 4.5-fold (0.66 log units), on the high side; measured number outside the range, below it.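

In this assay, for the compounds shown here, placing 3-chloro-5-(trifluoromethyl)phenyl on this nitrogen gives the first readable steps at this position: an at least 5.4-fold lower number from compound 3 to compound 4 (0.73 log units; beyond the scatter) in place of 3,5-dimethoxyphenyl, and an at least 5.4-fold lower number from compound 2 to compound 4 (0.73 log units; beyond the scatter) in place of 2-chloro-4-methylphenyl. The group on this nitrogen can therefore change growth inhibition by more than the scatter, which the unreadable earlier step could not show. Both steps start from a limit and not a number: the limit of > 30000 nM in this assay, at which 2 of the 4 values shown sit.

Whether the chlorine, the trifluoromethyl or the two together account for the change stays open. So does the effect of a phenyl ring carrying a nitrile or an amine here.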